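Replacing one phenyl group: compound 3 to compound 4

This account rests on a few compounds, and the source may have more. Where it says the series, first, only, none or still open, it means among the compounds named here.

Compound 1 `COc1cc2ncnc(Nc3ccc(F)c(Cl)c3)c2cc1NC(=O)N/N=C/c1cccc(Br)c1`: 27100 nM
Compound 2 `COc1cc2ncnc(Nc3ccc(F)c(Cl)c3)c2cc1NC(=O)N/N=C/c1cc(OC)c(OC)c(OC)c1`: 30700 nM
Compound 3 `COc1cc2ncnc(Nc3ccc(F)c(Cl)c3)c2cc1NC(=O)N/N=C/c1ccc(O)c(Br)c1`: "not active" (no number reported)

These results come from a functional assay on MCF7 cells (Homo sapiens) for cytotoxicity, read by MTT assay, with a stated time of 72 h; on this read-out lower numbers stand for stronger inhibition and higher numbers for weaker inhibition. On these data alone, compound 3 has no number there, only the verdict "not active" (no number reported), so its exact distance from the other two compounds is unknown.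

Compound 4 `COc1cc2ncnc(Nc3ccc(F)c(Cl)c3)c2cc1NC(=O)N/N=C/c1ccc(O)cc1O` keeps the shared core and changes one group, on a carbon with a double bond to nitrogen: 2,4-dihydroxyphenyl in place of 3-bromo-4-hydroxyphenyl (2,4-dihydroxyphenyl in place of 3-bromo-4-hydroxyphenyl on a carbon with a double bond to nitrogen).

Going by the values given here, only one measured step bears on this change. In it, a 1.1-fold higher number from compound 1 to compound 2 (0.05 log units; within the scatter), the group at this same place is swapped, and the result stays within the scatter. That is thin evidence, since this step involves neither group of the present pair. Among the compounds with values here, with no number for compound 3, no step from it can be sized or given a direction in this assay. The expectation therefore leans on compound 1 at 27100 nM and compound 2 at 30700 nM. Compound 4 will probably land in the same region, although it too may return no number. Compound 4 is expected at 30000 nM, with an estimated range of 12000 nM to 75000 nM.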

Compound 4, half-maximal inhibitory concentration: 36200 nM
The estimate for compound 4 lay 1.2-fold (0.08 log units) below the measured number, within the range that was stated.
By their numbers in this assay, from the lowest: compounds 1, 2 and 4 (each within the scatter of the next).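

In this assay compound 4 returns a number where compound 3 has only the verdict "not active", so replacing 3-bromo-4-hydroxyphenyl with 2,4-dihydroxyphenyl yields a measurable result, though every step involving compound 3 remains unreadable. A step of a 1.2-fold higher number from compound 2 to compound 4 (0.07 log units; within the scatter) and a step of a 1.3-fold higher number from compound 1 to compound 4 (0.13 log units; within the scatter) leave 3-bromophenyl, 3,4,5-trimethoxyphenyl and 2,4-dihydroxyphenyl on the carbon with a double bond to nitrogen indistinguishable in this read-out, with compound 3 the one exception among the four compounds shown. Nothing measured here accounts for that exception or for the similar numbers of the other three compounds.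

Still open, on these data alone, is whether a phenyl ring carrying a carboxylic acid or an amine, or a saturated carbon chain in place of the phenyl ring, would give a number beyond the scatter of these three. Also open, as far as these compounds go, is whether the bromine or the hydroxyl group of 3-bromo-4-hydroxyphenyl goes with the verdict on compound 3, a question that a plain 4-hydroxyphenyl group or a 3-bromo-4-methoxyphenyl group at this place could help to answer.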